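A few compounds are considered here, and "the series" means these few. Any claim that something is new, unique, unknown or untested is made for them only; others in the source may bear on it.

For the measured compounds named here, in a physicochemical assay for solubility, read by LC-MS, in phosphate buffer, with a stated time of 24 h, at pH 7.4 (a lower number here means a less soluble compound, a higher number a more soluble compound), compound 2 (`CC(=O)Nc1cc(Nc2cc(NC3CC3)n3ncc(C#N)c3n2)ccc1NCCCO`) stands at 2000 nM as the only exact number so far. Compound 1 (`CCN(CC)CCN(C)c1ccc(Nc2cc(NC3CC3)n3ncc(C#N)c3n2)cc1NC(C)=O`) reports > 1000000 nM as a limit of the assay and not a number. Going by the values given here, the one measured step bearing on the change is large, an at least 500-fold lower number from compound 1 to compound 2 (2.69 log units; beyond the scatter) with the (3-hydroxypropyl)amino group entering. On these data alone, it starts from the limit of > 1000000 nM in this assay, at which 1 of the 2 values shown sits, and so its full size stays open.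

Compound 3 (`CCN(CCN)c1ccc(Nc2cc(NC3CC3)n3ncc(C#N)c3n2)cc1NC(C)=O`) differs from compound 2 in one place, where a group of 6 heavy atoms (4 carbon, 2 nitrogen; no ring) in place of a group of 5 heavy atoms (3 carbon, 1 nitrogen, 1 oxygen; no ring), on an aromatic carbon on a carbon ortho to an acetamido group. The entering chain resembles the (2-(diethylamino)ethyl)(methyl)amino group of compound 1 more than the group it replaces, so a large rise in this assay is expected, reversing much of that step. The expected change is a 100-fold higher number from compound 2 to compound 3 (2.00 log units; beyond the scatter) and it remains an estimate. For compound 3 the estimated value is 200000 nM with an expected range from 20000 nM to 1000000 nM in this assay once measured.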

Compound 3, solubility: > 1000000 nM
Compound 3 gave a limit, no number; the forecaster's own chance of this, stated with the estimate: 30%; at least 5.0-fold (0.69 log units) between middle value and limit.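

In this assay, the group ortho to an acetamido group now has a second exchange to its name, and the entering chain gives an at least 500-fold higher number from compound 2 to compound 3 (2.69 log units; beyond the scatter), so a chain other than that of compound 1 also separates sharply from the (3-hydroxypropyl)amino group of compound 2. Compound 3 reports > 1000000 nM, which is a limit of the assay and not a number. Compound 1 and compound 3 both end at such a limit, so the step between them cannot be read and the two chains cannot be ranked: the limit of > 1000000 nM in this assay, at which 2 of the 3 values shown sit.

For the compounds shown here, the full size of the rise also stays open, with compound 2 still the only exact number. On these data alone, it remains unknown whether a (3-aminopropyl)amino group, or a carboxylic acid at the end of the chain, would read like compound 2 or like compound 3 at this place.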